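Series notes: amine change from compound 3 to compound 4

A few compounds are considered here, and "the series" means these few. Any claim that something is new, unique, unknown or untested is made for them only; others in the source may bear on it.

Compound 3 `CN(C)C/C=C/C(=O)Nc1cc2c(N3CCCc4ccccc43)ncnc2cc1O[C@@H]1CCOC1` gives 4170 nM in a functional assay on PC-3 cells (Homo sapiens) for antiproliferative activity, read by MTT assay, with a stated time of 72 h (on this read-out lower numbers stand for stronger inhibition and higher numbers for weaker inhibition), the lowest of the three numbers. Compound 1 `CC(C)=CC(=O)Nc1cc2c(N3CCCc4ccccc43)ncnc2cc1O[C@@H]1CCOC1` gives 9020 nM and compound 2 `C/C=C/C(=O)Nc1cc2c(N3CCCc4ccccc43)ncnc2cc1O[C@@H]1CCOC1` gives 9350 nM; the steps of a 2.2-fold lower number from compound 1 to compound 3 (0.34 log units; beyond the scatter) and a 2.2-fold lower number from compound 2 to compound 3 (0.35 log units; beyond the scatter) both lie beyond the scatter, so compound 3 is the most potent measured member. Compound 4 `CN1CCN(C/C=C/C(=O)Nc2cc3c(N4CCCc5ccccc54)ncnc3cc2O[C@@H]2CCOC2)CC1` carries 4-methylpiperazin-1-yl in place of dimethylamino on a saturated chain carbon bound to a double-bonded chain carbon. Going by the values given here, the only measured step touching that carbon is a 2.2-fold lower number from compound 2 to compound 3 (0.35 log units; beyond the scatter), where the amine first entered; no measured step exchanges one amine for another, so the size of this move is untested. The expected step of a 1.2-fold lower number from compound 3 to compound 4 (0.08 log units; within the scatter) is modest at most, staying near compound 3. Compound 4 is estimated at 3500 nM, with a range from 1500 nM to 8000 nM.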

Compound 4, half-maximal inhibitory concentration: 9450 nM
Compound 4: the middle estimate sits 2.7-fold (0.43 log units) below what was measured; the whole stated range lies below it.
By their numbers in this assay, from the lowest: compound 3; then compounds 1, 2 and 4 (each within the scatter of the next).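

In this assay the amine on the saturated chain carbon is not interchangeable: dimethylamino to 4-methylpiperazin-1-yl gives (a 2.3-fold higher number from compound 3 to compound 4 (0.36 log units; beyond the scatter)). The piperazine compound stands level with the amine-free crotonamide (a 1.0-fold higher number from compound 2 to compound 4 (0.00 log units; within the scatter)) and with the 2-methylprop-1-en-1-yl amide (a 1.0-fold higher number from compound 1 to compound 4 (0.02 log units; within the scatter)), so an amine at this place does not by itself carry the gain seen with compound 3. No evidence on the cause of this is at hand.

Still open, as far as these compounds go, is whether the loss follows the ring or the second ring nitrogen. Pyrrolidin-1-yl or morpholin-4-yl at this carbon would separate these.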